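The source may hold more compounds than are shown below. What is called first, only, known or untested is meant among the compounds shown, and "the series" means these compounds.

Compound 3 `COc1ccc(/C=C\C(=O)O)c(OCc2cn(-c3ccccc3C(=O)N3CCC(O)C3)nn2)c1CC=C(C)C` is one of three closely related acids built on a shared core. In a functional assay on HCT-116 cells (Homo sapiens) for cytotoxicity, read by MTT assay, with a stated time of 24 h (a higher number here means a weaker inhibitor, a lower number a stronger inhibitor), compound 3 gives 32000 nM. Among the measured compounds shown here, only one other measured number exists for comparison: compound 2 `COc1ccc(/C=C\C(=O)O)c(OCc2cn(-c3ccccc3)nn2)c1CC=C(C)C`, which carries hydrogen where compound 3 carries the (3-hydroxypyrrolidin-1-yl)carbonyl group, and in this assay compound 2 gives 26000 nM. The step of a 1.2-fold higher number from compound 2 to compound 3 (0.09 log units; within the scatter) shows that adding that group to the aromatic carbon changed nothing that the assay can resolve. Compound 3 therefore holds the higher of two numbers, but the gap to compound 2 carries no meaning. A third member, compound 1 `COc1ccc(/C=C\C(=O)O)c(OCc2cn(-c3ccc(NC(C)=O)cc3)nn2)c1CC=C(C)C`, stands in this assay with the entry "not determined" (no result reported), so compound 1 offers no number for comparison.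

Compound 4 `COc1ccc(/C=C\C(=O)O)c(OCc2cn(-c3ccccc3C#N)nn2)c1CC=C(C)C` arises from compound 3 by the change (cyano in place of (3-hydroxypyrrolidin-1-yl)carbonyl on an aromatic carbon). For the measured compounds named here, no measured step covers this exact exchange; the only step that bears on the same aromatic carbon is the one from compound 2 to compound 3, which was within the scatter. Since both a hydrogen and the larger group at this place gave indistinguishable numbers, the cyano group is expected to leave the number essentially where it is, with the step of a 1.1-fold lower number from compound 3 to compound 4 (0.06 log units; within the scatter) expected to stay within the scatter. In this assay compound 4 is therefore expected to give about 28000 nM, most likely between 12000 nM and 65000 nM.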

Compound 4, half-maximal inhibitory concentration: 38300 nM
Beside the measured number, compound 4's estimate is 1.4-fold (0.14 log units) below it; the range from low to high includes it.
By their numbers in this assay, from the lowest: compounds 2, 3 and 4 (each within the scatter of the next).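

With the nitrile in place, this aromatic carbon has now carried three quite different substituents in this assay, and none of them separates from the others. Replacing the (3-hydroxypyrrolidin-1-yl)carbonyl group, with 8 heavy atoms, a five-membered ring and 1 hydrogen-bond donor, by cyano, with 2 heavy atoms, no ring and 0 hydrogen-bond donors, gives a 1.2-fold higher number from compound 3 to compound 4 (0.08 log units; within the scatter) and so removes most of the substituent without a change the assay can resolve, while the direct comparison with hydrogen at the same carbon gives a 1.5-fold higher number from compound 2 to compound 4 (0.17 log units; within the scatter) and is equally unresolved. For these three compounds, then, the size of the group, the presence of its ring and the presence of its hydrogen-bond donor do not separate the numbers, and no measurement here offers an explanation for this.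

From the compounds shown here alone, whether an amine or a carboxylic acid on this aromatic carbon would also stay within the scatter remains open. So does whether a change elsewhere on the shared core, rather than at this carbon, would move the number beyond the scatter.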